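Changing the Chain End of Compound 1

The source may report more compounds than this note shows. Statements on the series, on what has been measured and on what is new or still open speak of the compounds shown alone.

Measured in a functional assay on MDA-MB-231 cells (Homo sapiens) for antiproliferative activity, read by MTT assay; a lower number here means a stronger inhibitor, a higher number a weaker inhibitor:
- Compound 1 `CCCC/C=C\CCCCCCCCCc1cc(=O)c2c(O)cc(O)c(C)c2o1`: 6790 nM
- Compound 2 `CCCCCCCCCCCCCCCc1cc(=O)c2c(O)c(C)c(OCOC)cc2o1`: > 87000 nM, a limit of the assay and not a number

Among the compounds with values here, compound 1, at 6790 nM, holds the only true number so far in this assay. The other result is the limit of > 87000 nM in this assay, at which 1 of the 2 values shown sits, and it belongs to compound 2.

Compound 3 `CCCCC/C=C\C/C=C\CCCCCCCc1cc(=O)c2c(O)cc(O)c(C)c2o1` has not been measured. It keeps the core of compound 1 and differs only in its long chain, with deca-1,4-dien-1-yl in place of oct-3-en-1-yl on a saturated chain carbon, seven bonds along the chain from an aromatic carbon.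

Within the data shown here, no measured pair shows what such a chain change does. With only compound 1 at 6790 nM as a guide, no change beyond the usual scatter is expected, in either direction. The expected step is small: a 1.1-fold higher number from compound 1 to compound 3 (0.04 log units; within the scatter). Compound 3 is estimated at 7500 nM, with an expected range from 2500 nM to 23000 nM.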

Compound 3, half-maximal inhibitory concentration: 6790 nM
For compound 3 the middle estimate is 1.1-fold (0.04 log units) above the measured one, within the range that was stated.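

In this assay, within the data shown here, putting deca-1,4-dien-1-yl in place of oct-3-en-1-yl gives no change at the digits printed from compound 1 to compound 3 (within the scatter), and this is the first direct comparison of two compounds that differ in one place. At this place on the chain, seven bonds along from an aromatic carbon, a longer tail with a second double bond therefore leaves the antiproliferative reading unchanged within the scatter. Nothing in the data shown explains why this change leaves the reading unchanged.

Still open, as far as these compounds go, is whether the chain end would accept something other than plain carbon, such as a carboxylic acid or an amine at its tip, or whether a much shorter chain would serve as well. Compound 2 differs from compound 1 in more than one place and its result is only a limit of the assay, so it cannot settle either question.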